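The source may report more compounds than this note shows. Statements on the series, on what has been measured and on what is new or still open speak of the compounds shown alone.

Series notes on the aryl-urea set in a functional assay on a cell-free system (plasma) with sterol O-acyltransferase, Soat (Rattus norvegicus) as the target; a lower number here means that less compound is needed, a higher number that more compound is needed for the effect. Among the measured compounds shown here, every value measured so far is a limit of the assay rather than a number. Compound 1 `Cc1cc(C)c(NC(=O)N(Cc2cccc(-c3nnn(C)n3)c2)C2CCCCCC2)c(C)c1` gives < 1 mg/kg, a limit (the limit of < 1 mg/kg in this assay, at which 1 of the 3 values shown sits). Compound 2 `CN(C)c1ccc(CN(Cc2cccc(-c3cc[nH]n3)c2)C(=O)Nc2c(F)cc(F)cc2F)cc1` gives < 0.32 mg/kg, also a limit (the limit of < 0.32 mg/kg in this assay, at which 1 of the 3 values shown sits). Compound 3 `COc1ccccc1CN(Cc1cccc(-c2cc[nH]n2)c1)C(=O)Nc1c(SC)cc(C)nc1SC` gives > 0.1 mg/kg, likewise a limit and not a number (the limit of > 0.1 mg/kg in this assay, at which 1 of the 3 values shown sits). For the measured compounds named here, with only limits in hand, no step between measured compounds can be computed, and compound 3 stands without a fixed place among the three; its sign points the opposite way from the other two, so nothing can be said of order.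

Compound 4 `CSc1cc(C)nc(SC)c1NC(=O)N(Cc1ccc(F)cc1)Cc1cccc(-c2cc[nH]n2)c1` differs from compound 3 by 4-fluorophenyl in place of 2-methoxyphenyl on a saturated chain carbon bound to an amide-type nitrogen. Going by the values given here, no measured pair carries this change, so no step size can be read from the data. The expectation is a step in this assay not beyond the usual scatter, in no particular direction. For compound 4 the value expected in this assay is 0.3 mg/kg, within 0.1 mg/kg to 1 mg/kg. The estimated step from compound 3 to compound 4 is a step that the limit leaves unreadable from compound 3 to compound 4, and a limit rather than a number is considered likely.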

Compound 4, dose for half-maximal effect: < 0.1 mg/kg
Compound 4 was reported as a limit (the forecaster's own chance of this, stated with the estimate: 70%); at least 3.0-fold (0.47 log units) between middle value and limit.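

Among the compounds shown here, this is the first pair in the set that differs in one place, and in this assay 4-fluorophenyl in place of 2-methoxyphenyl on a saturated chain carbon bound to an amide-type nitrogen gives a number no higher from compound 3 to compound 4 (the limit leaves the size open). The limits of compounds 3 and 4 point opposite ways, so this pair gives a direction, which the earlier limits could not. Compound 4 gives < 0.1 mg/kg, a limit and not a number, so on this core the position accepts 4-fluorobenzyl with no loss that the data can show.

Going by these compounds, the size of the step remains open, as does whether it follows from gaining the fluorine or from losing the methoxy group. A plain benzyl or a 4-methoxybenzyl group on the same core would separate the two.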